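Swapping a Methyl for a Nitrile on the Benzyl Arm

This account rests on a few compounds, and the source may have more. Where it says the series, first, only, none or still open, it means among the compounds named here.

Measured so far:
compound 1 `CSCC[C@H](NC(=O)c1ccc(NCc2cncn2Cc2cccc(C)c2)cc1-c1ccccc1)C(=O)O`: > 10 uM
compound 2 `COC(=O)[C@H](CCSC)NC(=O)c1ccc(CN(Cc2c[nH]cn2)Cc2c[nH]cn2)cc1-c1ccccc1C`: > 10 uM

In a functional assay on NIH3T3 cells (Mus musculus) (on this read-out lower numbers stand for an effect already at smaller amounts and higher numbers for an effect only at larger amounts of compound), compound 1 gives > 10 uM, which is a limit of the assay and not a number. Compound 2 gives > 10 uM in this assay, again a limit. Compound 1 therefore stands at the limit of > 10 uM in this assay, at which 2 of the 2 values shown sit.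

Compound 3 `CSCC[C@H](NC(=O)c1ccc(NCc2cncn2Cc2ccccc2C#N)cc1-c1ccccc1)C(=O)O` differs from compound 1 in one place: 2-cyanophenyl in place of 3-methylphenyl on a saturated chain carbon bound to an aromatic nitrogen. Going by the values given here, no measured step of this kind exists here, so a step in this assay of no more than the usual scatter, in no particular direction, is expected. The estimate for compound 3 is 20 uM, within 5 uM to 100 uM, an expected step that the limit leaves unreadable from compound 1 to compound 3.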

Compound 3, concentration for half-maximal effect: > 10 uM
Compound 3: no number, only a limit; the forecaster's own chance of this, stated with the estimate: 75%; the middle value lies beyond the limit too.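

In this assay, going by these compounds alone, compound 3 gives > 10 uM, again a limit and not a number, so no step from compound 1 to this compound can be read. The compounds shown leave open whether changing 3-methylbenzyl to 2-cyanobenzyl alters the effect at all.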